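From 3,4-Dimethoxyphenyl to 4-Bromophenyl on the Shared Core

This account rests on a few compounds, and the source may have more. Where it says the series, first, only, none or still open, it means among the compounds named here.

Of the compounds shown here, two with a shared core have been measured so far. In a functional assay on the whole organism (strain Kunming) with Mus musculus as the target, with a stated time of 0.5 h (on this read-out lower numbers stand for an effect already at smaller amounts and higher numbers for an effect only at larger amounts of compound), compound 1 `COc1ccccc1/C=C/C(=O)OC/C=C/c1cc(OC)c(OC)cc1OC` gives 625 umol/kg, and compound 2 `COc1cc(OC)c(OC)cc1/C=C/COC(=O)/C=C/c1ccc(OC)c(OC)c1` gives 418 umol/kg. Among the measured compounds shown here, the only comparison available for compound 2 is a 1.5-fold lower number from compound 1 to compound 2 (0.17 log units; within the scatter), so these two numbers cannot be told apart.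

Compound 3 `COc1cc(OC)c(OC)cc1/C=C/COC(=O)/C=C/c1ccc(Br)cc1` has not yet been measured. The structural change from compound 2 is 4-bromophenyl in place of 3,4-dimethoxyphenyl on a double-bonded chain carbon bound to a double-bonded chain carbon. In words, 4-bromophenyl takes the place of 3,4-dimethoxyphenyl on a double-bonded chain carbon bound to a double-bonded chain carbon. For the measured compounds named here, the single measured step changed the group at this same place, but no measured compound carries 4-bromophenyl, so the evidence is indirect.

The exchange at this place in a 1.5-fold lower number from compound 1 to compound 2 (0.17 log units; within the scatter) stayed inside the scatter, so no step beyond the scatter is expected in this assay, and no direction can be favoured. The expected change is a 1.0-fold lower number from compound 2 to compound 3 (0.02 log units; within the scatter). For compound 3 the estimated value is 400 umol/kg, with an expected range from 170 umol/kg to 950 umol/kg.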

Compound 3, dose for half-maximal effect: 446 umol/kg
For compound 3 the middle estimate is 1.1-fold (0.05 log units) below the measured one; measured number inside the range.
By their numbers in this assay, from the lowest: compounds 2, 3 and 1 (each within the scatter of the next).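

In this assay the exchange brings a 1.1-fold higher number from compound 2 to compound 3 (0.03 log units; within the scatter) and, read against the other measured group, a 1.4-fold lower number from compound 1 to compound 3 (0.15 log units; within the scatter), so three different groups on a double-bonded chain carbon bound to a double-bonded chain carbon now give numbers that cannot be told apart. The earlier pair showed this only for two methoxy-bearing phenyl groups, whereas 4-bromophenyl carries no methoxy group at all: the group that leaves has 10 heavy atoms and 2 hydrogen-bond acceptors, the one that enters has 7 heavy atoms and 0 hydrogen-bond acceptors, and the number still stays within the scatter. No accompanying measurement bears on this result, so nothing can be said about what lies behind it.

On these data alone, all three compounds carry a substituted phenyl group at this place, so it remains open whether a phenyl group bearing an amine or a carboxylic acid, or a longer chain in place of the phenyl group, would move the number beyond the scatter. As far as these compounds go, the rest of the shared core is the same in all three compounds, so what an exchange elsewhere would do in this assay also remains open.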